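This account rests on a few compounds, and the source may have more. Where it says the series, first, only, none or still open, it means among the compounds named here.

Compound 1 `O=c1cc(-c2ccccc2)oc2ccc(OCCCN3CCC(O)CC3)cc12` was examined in an assay on isolated protein (Cavia porcellus) with Sigma non-opioid intracellular receptor 1 (Homo sapiens) as the target, read by radioligand binding (a lower number here means a stronger inhibitor, a higher number a weaker inhibitor), where compound 1 gives 123 nM. Of the two numbers in hand this is the highest; the nearest is compound 2 `O=c1cc(-c2ccccc2)oc2cc(OCCCCCCN3CCC(O)CC3)ccc12`, which in this assay gives 70 nM, and the two values lie within the scatter of each other, so no order can be read from them. From compound 1 the account moves to compound 3 `NCCCCCCOc1ccc2oc(-c3ccccc3)cc(=O)c2c1`, which still awaits measurement in this assay. The difference between the two structures is 3-aminopropyl in place of 4-hydroxypiperidin-1-yl on a saturated chain carbon, three bonds along the chain from an oxygen on an aromatic ring. For the measured compounds named here, no measured step of this kind exists among the compounds at hand, so the expectation rests on the structural change alone. The step from compound 1 to compound 3 is estimated at a 3.3-fold higher number from compound 1 to compound 3 (0.51 log units; beyond the scatter), toward a higher number and beyond the scatter. Compound 3 is accordingly expected to give 400 nM in this assay, within a range from 100 nM to 2000 nM.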

Compound 3, half-maximal inhibitory concentration: 3700 nM
Beside the measured number, compound 3's estimate is 9.3-fold (0.97 log units) below it; measured number outside the range, above it.
By their numbers in this assay, from the lowest: compounds 2 and 1 (each within the scatter of the next); then compound 3.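

In this assay, the group on a saturated chain carbon, three bonds along the chain from an oxygen on an aromatic ring, proves not to be freely exchangeable: 3-aminopropyl in place of 4-hydroxypiperidin-1-yl gives a 30-fold higher number from compound 1 to compound 3 (1.48 log units; beyond the scatter) and is a large step. For the compounds shown here, this is the first comparison here of two compounds that differ in one place, and it shows that the number responds strongly to what is attached at this position. Nothing at hand accounts for the size of the step.

The compounds shown leave open which part of the exchange carries the step: the ring, its hydroxyl or the open chain that replaces them. A plain piperidin-1-yl, a morpholin-4-yl or a dimethylamino group at this place would bear on that question.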